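Replacing isopropyl by pyridin-4-yl on the ring amine nitrogen

This account rests on a few compounds, and the source may have more. Where it says the series, first, only, none or still open, it means among the compounds named here.

Compound 1 `CC(C)N1CCN(Cc2csc(N)c2C(=O)c2ccc(Cl)cc2)CC1` carries an isopropyl on an amine nitrogen in a ring of the shared core. In a functional assay on CHO cells with adenosine receptor A1 (Homo sapiens) as the target, read by cAMP accumulation and immunoassay, with a stated time of 6 min, tested at 0.01 uM (a lower number here means a stronger effect, a higher number a weaker effect of the compound at the concentration tested), compound 1 gives -1%. Among the three measured compounds this is the second highest number; the nearest is compound 3 `Nc1scc(CN2CCN(c3ccc(Cl)c(C(F)(F)F)c3)CC2)c1C(=O)c1ccc(Cl)cc1` with -2.5%, the furthest compound 2 `Nc1scc(CN2CCN(c3ccc(F)cc3Cl)CC2)c1C(=O)c1ccc(Cl)cc1` with 6.1%. The steps of a number 7.1 percentage points higher from compound 1 to compound 2 (within the scatter) and a number 1.5 percentage points lower from compound 1 to compound 3 (within the scatter) both lie within the scatter, as does a number 8.6 percentage points lower from compound 2 to compound 3 (within the scatter). Compound 4 `Nc1scc(CN2CCN(c3ccncc3)CC2)c1C(=O)c1ccc(Cl)cc1` is not yet measured in this assay. It differs from compound 1 by pyridin-4-yl in place of isopropyl on an amine nitrogen in a ring. The two measured steps from compound 1 bear on this change, since each also exchanged the isopropyl on that ring nitrogen for an aromatic ring, and neither moved the number beyond the scatter. Going by the values given here, no larger step is therefore expected here, and the expected step is a number 2 percentage points higher from compound 1 to compound 4 (within the scatter). For compound 4 the estimate in this assay is 1%, with a range from -11% to 13%.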

Compound 4, a percentage reported as activity, at one concentration (the size of the read-out at that concentration, not a potency): -4%
Estimate against measurement, compound 4: 5 percentage points above, and the stated range covers the measured number.
By their numbers in this assay, from the lowest: compounds 4, 3, 1 and 2 (each within the scatter of the next, the first and the last beyond it).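

In this assay a ring with a hetero atom and a hydrogen-bond acceptor now sits on the ring nitrogen, and replacing isopropyl with it gives a number 3 percentage points lower from compound 1 to compound 4 (within the scatter), while replacing the 4-chloro-3-(trifluoromethyl)phenyl gives a number 1.5 percentage points lower from compound 3 to compound 4 (within the scatter). Going by these compounds alone, replacing the 2-chloro-4-fluorophenyl gives a number 10.1 percentage points lower from compound 2 to compound 4 (beyond the scatter), the first step at this position to pass the scatter, and a modest one. Compound 2 takes part in this step, whereas the steps among compounds 1, 3 and 4 stay within the scatter. No measurement at hand accounts for the size of this step.

Open, going by these compounds, is whether an amine, a carboxylic acid or a longer alkyl chain on the ring nitrogen would leave the number within the scatter. On these data alone, the read-out stands at one concentration, so potency across these groups also stays open.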